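Swapping Selenium for Sulfur on a Quinoline-Free Shared Core

The source may hold more compounds than are shown below. What is called first, only, known or untested is meant among the compounds shown, and "the series" means these compounds.

Measured so far:
Compound 1, `OCC#CCSc1cnc2ccccc2c1SCC#CCO`: 42.2 ug/mL
Compound 2, `C#CCSc1cnc2ccccc2c1SCC#CCO`: 54.7 ug/mL
Compound 3, `CSc1cnc2ccccc2c1[Se]CC#CCO`: 4.2 ug/mL

Of the compounds shown here, three built on one shared core have been tested in a functional assay on B16 cells (Mus musculus) for cytotoxicity, read by sulforhodamine B assay, with a stated time of 72 h; on this read-out higher numbers stand for weaker inhibition and lower numbers for stronger inhibition. Compound 1 and compound 2 differ only in that compound 2 carries hydrogen in place of hydroxymethyl on a triple-bonded carbon, and that step, a 1.3-fold higher number from compound 1 to compound 2 (0.11 log units; within the scatter), is too small to count. Compound 3 stands apart: its number is the lowest of the three, with a gap to compound 1 and a larger one to compound 2, both beyond the scatter.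

The next compound, compound 4, `CSc1cnc2ccccc2c1SCC#CCO`, is reached from compound 3 by one change: a group of 6 heavy atoms (4 carbon, 1 oxygen, 1 sulfur; no ring) in place of a group of 6 heavy atoms (4 carbon, 1 oxygen, 1 selenium; no ring), on an aromatic carbon. For the measured compounds named here, no measured pair shows this exchange of selenium for sulfur, so the only step in hand, the one from compound 1 to compound 2, does not bear on it directly. What the numbers do show is that compound 1 and compound 2, which carry sulfur in both side positions, sit well above compound 3. On that basis a rise is expected for compound 4, estimated as a 2.9-fold higher number from compound 3 to compound 4 (0.46 log units; beyond the scatter), landing it between compound 3 and compound 1. The estimate for compound 4 in this assay is 12 ug/mL, with a range from 4 ug/mL to 40 ug/mL.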

Compound 4, concentration for 50% inhibition: 49.8 ug/mL
For compound 4 the middle estimate is 4.2-fold (0.62 log units) below the measured one; the measured number lies above the stated range.
By their numbers in this assay, from the lowest: compound 3; then compounds 1, 4 and 2 (each within the scatter of the next).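

In this assay, for the compounds shown here, replacing the selenium-linked chain with its sulfur-linked counterpart on this aromatic carbon gives a 12-fold higher number from compound 3 to compound 4 (1.07 log units; beyond the scatter) and is a large step, which ties the low number of compound 3 to the selenium atom in a direct one-place comparison that the earlier compounds could not offer. On the other side of the shared core, the methylsulfanyl group of compound 4 reads no differently from the longer sulfur-linked chains, since a 1.1-fold lower number from compound 2 to compound 4 (0.04 log units; within the scatter) and a 1.2-fold higher number from compound 1 to compound 4 (0.07 log units; within the scatter) are both within the scatter, so hydrogen, ethynyl and 3-hydroxyprop-1-yn-1-yl on that saturated chain carbon bound to a sulfur cannot be told apart while sulfur occupies the other position. Nothing available here explains why this single atom exchange matters so much.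

The compounds shown leave open whether selenium gives the same drop when its chain ends in an amine or a carboxylic acid rather than a hydroxyl group. They also leave open whether selenium in place of the sulfur of the methylsulfanyl group would change the number at all.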